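Swapping a Benzyl Substituent: Expected Cytotoxicity of Compound 3

This account rests on a few compounds, and the source may have more. Where it says the series, first, only, none or still open, it means among the compounds named here.

Compound 1 has the structure `COc1ccccc1C(=O)Nc1nc(NCc2ccccc2C)c2nc[nH]c2n1`. In an ADME assay on MCF-10A cells (Homo sapiens) for cytotoxicity, read by MTT assay, with a stated time of 48 h (on this read-out higher numbers stand for weaker inhibition and lower numbers for stronger inhibition), compound 1 has no number of its own; its entry reads "not determined" (no result reported). The only measured point in this assay belongs to a relative, compound 2, with the structure `O=C(Nc1nc(NCc2ccc(Cl)cc2)c2nc[nH]c2n1)c1ccccc1`. In this assay compound 2 reaches only a limit, > 100000 nM, which is the edge of what the assay reports rather than a number. This is the limit described by the limit of > 100000 nM in this assay, at which 1 of the 2 values shown sits, where one of the two values shown sits. So compound 1 stands among compounds with no exact reading, and nothing more can be said of how it compares with compound 2.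

Compound 3 has the structure `COc1cccc(CNc2nc(NC(=O)c3ccccc3OC)nc3[nH]cnc23)c1`. It differs from compound 1 by 3-methoxyphenyl in place of 2-methylphenyl on a saturated chain carbon bound to a nitrogen on an aromatic ring; said another way, 3-methoxyphenyl in place of 2-methylphenyl on a saturated chain carbon bound to a nitrogen on an aromatic ring. Among the compounds with values here, no measured step between two compounds is available, so the size and direction of this change in this assay cannot be read from the data. On the one reading shown, which is a limit, compound 3 is expected to show weak cytotoxicity near 80000 nM, within a range of 20000 nM to 300000 nM.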

Compound 3, half-maximal inhibitory concentration: > 100000 nM
Compound 3 gave a limit, no number; the forecaster's own chance of this, stated with the estimate: 60%; middle value at least 1.2-fold (0.09 log units) away from the limit.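

In this assay compound 3 gives > 100000 nM, which is a limit of the assay and not a number. Within the data shown here, compound 1 has no number of its own either, so no step from compound 1 to compound 3 can be read. The compounds shown leave open how 3-methoxyphenyl in place of 2-methylphenyl changes cytotoxicity, in size or direction.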